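A few compounds are considered here, and "the series" means these few. Any claim that something is new, unique, unknown or untested is made for them only; others in the source may bear on it.

Three analogues on the shared core have been measured in an assay on mitochondria from L6 cells (Rattus norvegicus) for activation, with a stated time of 90 min; a lower number here means that less compound is needed, a higher number that more compound is needed for the effect: compound 1 `Fc1cc(F)cc(Nc2nc3nonc3nc2Nc2cc(F)cc(F)c2)c1`, compound 2 `FC(F)(F)Oc1ccc(Nc2nc3nonc3nc2Nc2ccc(OC(F)(F)F)cc2)cc1` and compound 3 `Fc1ccccc1Nc1nc2nonc2nc1NC1CCCCC1`. Compound 1 returns only a limit, < 1000 nM, which is the limit of < 1000 nM in this assay, at which 1 of the 3 values shown sits. Compound 2 also returns a limit, < 5000 nM, which is the limit of < 5000 nM in this assay, at which 1 of the 3 values shown sits. For the measured compounds named here, compound 3 is the one compound with an actual number, 13400 nM, so it stands as the sole fixed point of the set. Compound 4 `Fc1ccccc1Nc1nc2nonc2nc1Nc1ccccn1` differs from compound 3 by pyridin-2-yl in place of cyclohexyl on a nitrogen on an aromatic ring. Compound 3 carries the cyclohexyl and gives 13400 nM. Compounds 1 and 2 carry no cyclohexyl and each returns only a limit. For this reason a step toward lower values in this assay is expected for a 3.4-fold lower number from compound 3 to compound 4 (0.53 log units; beyond the scatter), beyond the usual scatter. Compound 4 is estimated at 4000 nM, with a range of 1500 nM to 12000 nM.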

Compound 4, half-maximal effective concentration: 9000 nM
Compound 4: the middle estimate sits 2.3-fold (0.35 log units) below what was measured; low and high end bracket the measured number.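

In this assay, pyridin-2-yl in place of cyclohexyl gives a 1.5-fold lower number from compound 3 to compound 4 (0.17 log units; within the scatter), so at this nitrogen an aromatic ring with a hetero atom and a non-aromatic ring of carbon only read the same. For the compounds shown here, this is the first single-place change on the shared core that can be read, and it shows no shift beyond the scatter. No measured property given here bears on this result.

Open, on these data alone, is whether pyridin-3-yl, phenyl or a piperidine ring on this nitrogen would read the same. Also open, as far as these compounds go, is whether a short alkyl chain or a carboxylic acid would move the value beyond the scatter.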